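The compounds below may be only part of what the source reports. "The series", "measured", "known", "first", "only" and "open" are said of these compounds alone.

Of the compounds shown here, two of one shared core have been tested. Compound 1 `O=C(N/N=C/c1cccc(O)c1)c1cccnc1Nc1cccc(C(F)(F)F)c1` carries a 3-hydroxyphenyl on the carbon with a double bond to nitrogen, and in a functional assay on the whole organism (strain Wistar) for inhibition, with Rattus norvegicus as the target, read by paw edema, with a stated time of 2 h, at a dose of 10 mg/kg by the intraperitoneal route (on this read-out lower numbers stand for less inhibition and higher numbers for more inhibition at the one dose given (going by the name of the read-out)), compound 1 gives 65.4%. Compound 2 `COc1ccc(/C=N/NC(=O)c2cccnc2Nc2cccc(C(F)(F)F)c2)c(OC)c1` carries a 2,4-dimethoxyphenyl in the same place, and in this assay compound 2 gives 44.7%. For the measured compounds named here, the single step of a number 20.7 percentage points lower from compound 1 to compound 2 (beyond the scatter) is the only comparison available. Going by the values given here, on these two numbers compound 2 stands lowest, with compound 1 the only neighbour and clearly higher.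

Compound 3 `CN(C)c1ccc(/C=N/NC(=O)c2cccnc2Nc2cccc(C(F)(F)F)c2)cc1` differs from compound 2 in one place: 4-(dimethylamino)phenyl in place of 2,4-dimethoxyphenyl on a carbon with a double bond to nitrogen. Among the compounds with values here, only the step from compound 1 to compound 2 bears on this change, and it concerns a different pair of groups, so it gives a direction only loosely. Both compound 2 and compound 3 lack a hydrogen-bond donor on the entering ring, which suggests compound 3 may sit near compound 2 rather than near compound 1. A step of no clear size beyond the scatter is therefore expected, a number 3.3 percentage points higher from compound 2 to compound 3 (within the scatter). Compound 3 is estimated to give 48% in this assay, within a range from 30% to 66%.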

Compound 3, a percentage reported as inhibition, in the whole organism at one dose (the size of the read-out at that dose, not a potency): 51.4%
Beside the measured number, compound 3's estimate is 3.4 percentage points below it; the measured number falls inside the stated range.
By their numbers in this assay, from the lowest: compounds 2 and 3 (each within the scatter of the next); then compound 1.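

In this assay, putting 4-(dimethylamino)phenyl in place of 2,4-dimethoxyphenyl on a carbon with a double bond to nitrogen gives a number 6.7 percentage points higher from compound 2 to compound 3 (within the scatter), so these two different groups cannot be told apart at this position in this test. The second step, a number 14 percentage points lower from compound 1 to compound 3 (beyond the scatter), shows that the loss seen with compound 2 is not peculiar to the 2,4-dimethoxyphenyl group: a second replacement of the 3-hydroxyphenyl also falls short, and compound 1 now stands clearly above both other compounds. No supporting measurement is available to explain why compound 1 stands apart from the other two.

The three groups differ in several ways at once, so these compounds cannot show whether the hydroxyl itself matters or where it sits on the ring. An unsubstituted phenyl, a 4-hydroxyphenyl and a 3-methoxyphenyl would help to separate these questions, while a pyridine ring at the same place would show whether a ring that is not carbon only is accepted there.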